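Lactone-to-oxane swap on the thioether arm of compound 2

The source may report more compounds than this note shows. Statements on the series, on what has been measured and on what is new or still open speak of the compounds shown alone.

Measured so far:
compound 1 `CC(C)c1ccc(-c2nc(SC[C@H]3C[C@@](C)(O)CC(=O)O3)[nH]c2-c2ccc(C(C)C)cc2)cc1.CC(C)c1ccc(-c2nc(SC[C@H]3C[C@](C)(O)CC(=O)O3)[nH]c2-c2ccc(C(C)C)cc2)cc1`: 230 nM
compound 2 `O=C1CCCC(CSc2nc(-c3ccccc3)c(-c3ccccc3)[nH]2)O1`: 740 nM

In an assay on microsomes from liver for inhibition of sterol O-acyltransferase 1 (Rattus norvegicus) (on this read-out higher numbers stand for weaker inhibition and lower numbers for stronger inhibition), compound 2 gives the highest of the two numbers recorded; compound 1 gives a lower number, and the gap between the two lies beyond the usual scatter. Within the data shown here, the two compounds differ in several places at once, so no single step is counted between them.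

Compound 3 `c1ccc(-c2nc(SCC3CCCCO3)[nH]c2-c2ccccc2)cc1` is not yet measured. It differs from compound 2 by a group of 6 heavy atoms (5 carbon, 1 oxygen; one six-membered non-aromatic ring with 1 hetero atom) in place of a group of 7 heavy atoms (5 carbon, 2 oxygen; one six-membered non-aromatic ring with 1 hetero atom), on a saturated chain carbon bound to a sulfur. Among the measured compounds shown here, no measured pair in this set mirrors this change, so the direction of the step is not anchored by data. The carbonyl of the lactone is lost while the ring size and its single hetero atom are kept; the working expectation is a step from compound 2 to compound 3 of a 1.4-fold higher number from compound 2 to compound 3 (0.13 log units; within the scatter), most likely within the scatter or somewhat weaker. Compound 3 is therefore estimated at 1000 nM, with a range from 300 nM to 3500 nM.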

Compound 3, half-maximal inhibitory concentration: 210 nM
Beside the measured number, compound 3's estimate is 4.8-fold (0.68 log units) above it; the measured number lies below the stated range.
By their numbers in this assay, from the lowest: compounds 3 and 1 (each within the scatter of the next); then compound 2.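

In this assay, a 3.5-fold lower number from compound 2 to compound 3 (0.55 log units; beyond the scatter), a step beyond the usual scatter, with oxan-2-yl replacing the lactone ring on a saturated chain carbon bound to a sulfur. This single-place change shows that, on the core of compound 2, the lactone carbonyl is not required for inhibition, since the number falls once the carbonyl is gone and the ring size and its single hetero atom are kept. No measurement at hand accounts for the size or direction of this step.

From the compounds shown here alone, whether the same swap carries over to the core of compound 1, with its substituted lactone and isopropyl groups, remains open. Also open, going by these compounds, is whether the ring oxygen itself matters, which a cyclohexyl or piperidin-2-yl group at this place would test.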